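Shortening the Side Chain of Compound 3 by One Carbon

The compounds below may be only part of what the source reports. "The series", "measured", "known", "first", "only" and "open" are said of these compounds alone.

Compound 1, `COc1ccc2c(C)cc(N/N=C/c3ccccc3O)nc2c1`: 2000 nM
Compound 2, `COc1ccc2ccccc2c1-c1cc(C(=O)N/N=C/c2cccs2)[nH]n1`: 5700 nM
Compound 3, `CCCCCCc1[nH]c2cc(OC)ccc2c1C(=O)c1cc(OC)c(OC)c(OC)c1`: 37.8 nM

Of the compounds shown here, three have been measured in a functional assay on KB cells (Homo sapiens) for inhibition; a lower number here means a stronger inhibitor, a higher number a weaker inhibitor. Compound 3 gives the lowest number of the three, and its separation from both compound 1 and compound 2 is beyond the scatter, so compound 3 is the most potent of the measured set. Compound 1 and compound 2, with their different cores, give clearly higher numbers.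

Compound 4, `CCCCCc1[nH]c2cc(OC)ccc2c1C(=O)c1cc(OC)c(OC)c(OC)c1`, has not yet been measured. It differs from compound 3 in one place: hydrogen in place of methyl on a saturated chain carbon, five bonds along the chain from an aromatic carbon. Within the data shown here, no pair of measured compounds differs in only one place, so no measured step of this kind is available for comparison. Trimming a methyl from the end of a saturated chain is a small change, and the expectation for compound 4 is a step of a 1.1-fold higher number from compound 3 to compound 4 (0.02 log units; within the scatter) that stays within the scatter, with no clear direction. Compound 4 is therefore estimated at 40 nM, with a range from 15 nM to 120 nM.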

Compound 4, half-maximal inhibitory concentration: 38 nM
The estimate for compound 4 lay 1.1-fold (0.02 log units) above the measured number, and the stated range covers the measured number.
By their numbers in this assay, from the lowest: compounds 3 and 4 (each within the scatter of the next); then compound 1; then compound 2.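

In this assay, hydrogen in place of methyl on a saturated chain carbon, five bonds along the chain from an aromatic carbon, gives a 1.0-fold higher number from compound 3 to compound 4 (0.00 log units; within the scatter). Among these compounds, this is the first one-place comparison in the set, and it shows that this methyl at the end of the chain can be removed from the shared core without a shift beyond the scatter. No measurement on hand offers an explanation for this result.

Because only this one step on the chain is shown, it remains open whether a much shorter chain, a longer chain, or an amine or a carboxylic acid at the end of the chain would keep the number in the same place. Compound 1 and compound 2 differ from this pair in more than one place, so they cannot settle that question.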